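The source may hold more compounds than are shown below. What is called first, only, known or untested is meant among the compounds shown, and "the series" means these compounds.

Compound 1 `CCC(C)[C@H](N)c1cc(C(F)(F)F)ccc1N1CCN(C(=O)CCc2ccc(OC)c(OC)c2Cl)CC1`: 2500 nM
Compound 2 `CC(C)C[C@H](N)c1cc(C(F)(F)F)ccc1N1CCN(C(=O)CCc2c[nH]c3ccccc23)CC1`: 640 nM
Compound 3 `CCN[C@H](c1cc(C(F)(F)F)ccc1N1CCN(C(=O)CCc2ccc(Cl)cc2Cl)CC1)C(C)CC`: 92 nM

In an assay on HEK293 cells for displacement of a labelled ligand from Melanocortin receptor 4 (Homo sapiens) (a lower number here means a stronger inhibitor, a higher number a weaker inhibitor), compound 3 gives the lowest number of the three. Compound 2 sits closest to it, yet its value of 640 nM is still clearly beyond the scatter, and compound 1 with 2500 nM lies further off again. For the measured compounds named here, the three compounds differ from one another in several places at once, so no single structural step between measured compounds can be read from these numbers.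

Compound 4 `CCC(C)[C@H](NC(=O)OC)c1cc(C(F)(F)F)ccc1N1CCN(C(=O)CCc2ccc(Cl)cc2Cl)CC1` is the one not yet measured. It is derived from compound 3 by a single change: methoxycarbonyl in place of ethyl on an amine nitrogen. Going by the values given here, since no measured pair isolates a change at this amine nitrogen, the size of the step in this assay is an open question. Among the compounds with values here, the account expects the number for compound 4 to move upward, that is toward a weaker inhibitor, by a step of about a 9.8-fold higher number from compound 3 to compound 4 (0.99 log units; beyond the scatter), though this expectation rests on no measured precedent in the set. Compound 4 is therefore estimated at 900 nM, within a range from 150 nM to 5000 nM.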

Compound 4, inhibition constant: 2400 nM
Beside the measured number, compound 4's estimate is 2.7-fold (0.43 log units) below it, and the stated range covers the measured number.
By their numbers in this assay, from the lowest: compound 3; then compound 2; then compounds 4 and 1 (each within the scatter of the next).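

For the compounds shown here, compound 3 and compound 4 form the first pair here that differs in one place only, so the amine nitrogen can now be read directly: in this assay, methoxycarbonyl in place of ethyl gives a 26-fold higher number from compound 3 to compound 4 (1.42 log units; beyond the scatter). Going by these compounds alone, the substituent on this nitrogen therefore matters greatly in this assay, a point that the earlier compounds, which differ in several places at once, could not show. Nothing available explains the size of this step.

Within the data shown here, compound 1 and compound 2 carry an unsubstituted amine but also differ elsewhere, so no step to or from them can be read. From the compounds shown here alone, it remains open how an acetyl group or a longer alkyl chain such as propyl on this nitrogen would compare, and so whether the step follows the carbonyl or the methoxy part of the new group.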